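Hydroxyalkyl variation on the amine of the shared core

The source may report more compounds than this note shows. Statements on the series, on what has been measured and on what is new or still open speak of the compounds shown alone.

Compound 1 `CC[C@H](Nc1nc(NCc2ccccn2)c2ncn(C(C)C)c2n1)C(C)(C)O` is the reference point. In a functional assay on HT-29 cells (Homo sapiens) for inhibition, read by sulforhodamine B assay, with a stated time of 96 h (a higher number here means a weaker inhibitor of growth, a lower number a stronger inhibitor of growth), compound 1 gives > 50000 nM, which is a limit of the assay and not a number. Compound 2 `CCC(O)[C@H](CC)Nc1nc(NCc2ccccn2)c2ncn(C(C)C)c2n1` carries 1-ethyl-2-hydroxybutyl on a nitrogen on an aromatic ring; in this assay compound 2 gives > 50000 nM, again only a limit. Compound 3 `CC[C@@H](Nc1nc(NCc2ccccn2)c2ncn(C(C)C)c2n1)C(O)C(C)(C)C` gives 34000 nM in this assay. The measured steps are a step that the two limits leave unreadable from compound 1 to compound 2, an at least 1.4-fold lower number from compound 1 to compound 3 (0.16 log units; that floor lies within the scatter) and an at least 1.4-fold lower number from compound 2 to compound 3 (0.16 log units; that floor lies within the scatter). Compound 1 thus stands only as a limit, in line with the limit of > 50000 nM in this assay, at which 2 of the 3 values shown sit.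

Compound 4 `CCC(O)[C@@H](CC)Nc1nc(NCc2ccccn2)c2ncn(C(C)C)c2n1` differs from compound 1 by 1-ethyl-2-hydroxybutyl in place of 1-(1-hydroxy-1-methylethyl)propyl on a nitrogen on an aromatic ring. The step from compound 1 to compound 2 bears most directly on it, yet its size stays unreadable because the limit of > 50000 nM in this assay, at which 2 of the 3 values shown sit, caps both ends; the steps to compound 3 are small and within the scatter. No change beyond the scatter is therefore expected, and compound 4 is expected to stay near the limit, the expected step being a step that the limit leaves unreadable from compound 1 to compound 4. Compound 4 is estimated at 60000 nM, with a range of 25000 nM to 150000 nM.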

Compound 4, concentration for 50% growth inhibition: > 50000 nM
Compound 4: no number, only a limit; the forecaster's own chance of this, stated with the estimate: 70%; the middle value is on the limit's open side.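

In this assay compound 4 gives > 50000 nM, which is a limit of the assay and not a number. For the compounds shown here, the exchange of tert-butyl for ethyl on this chain now has a step of its own, an at least 1.4-fold higher number from compound 3 to compound 4 (0.16 log units; that floor lies within the scatter), so the only measured number in the set, that of compound 3, is not yet separated from the limit compounds by more than the scatter. The steps from compound 1 to compound 4 and from compound 2 to compound 4 cannot be read, and neither the rearranged hydroxyalkyl chain nor the change in drawn configuration receives a size: the limit of > 50000 nM in this assay, at which 3 of the 4 values shown sit.

On these data alone, the pair compound 2 and compound 4 also gives no clean comparison of two defined configurations: the fact that one of compounds 2 and 4 is drawn with a defined configuration and the other without, at the place where they differ Whether an amine in place of the hydroxyl, or a longer chain, would bring the series clear of the limit stays open.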